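The source may report more compounds than this note shows. Statements on the series, on what has been measured and on what is new or still open speak of the compounds shown alone.

Measured in an ADME assay on microsomes from liver (Rattus norvegicus) for metabolic stability, read by LC-MS, with a stated time of 1 h, at 37 degrees C, tested at 4 uM; on this read-out higher numbers stand for a more stable compound and lower numbers for a less stable compound:
Compound 1 `COc1ccc(C(=O)O)cc1-c1cccc(COc2ccc3c(c2)CN(C2CCCC2)C3=O)c1`: 30%
Compound 2 `O=C(O)c1cc(-c2cccc(COc3ccc4c(c3)CN(C3CCCC3)C4=O)c2)ccc1O`: 9%
Compound 3 `O=C1c2ccc(OCc3cccc(-c4ccc(C(F)(F)F)cc4F)c3)cc2CN1C1CCCC1`: "not determined" (no result reported)

Compound 3 has no number in this assay, so it gives no starting point on this scale. Compound 4 `O=C(O)c1ccc(Cl)c(-c2cccc(COc3ccc4c(c3)CN(C3CCCC3)C4=O)c2)c1` differs from it by 5-carboxy-2-chlorophenyl in place of 2-fluoro-4-(trifluoromethyl)phenyl on an aromatic carbon, with 5-carboxy-2-chlorophenyl in place of 2-fluoro-4-(trifluoromethyl)phenyl on an aromatic carbon. For the measured compounds named here, no step from compound 3 can therefore be sized or given a direction. Going by the values given here, the one measured step, a number 21 percentage points lower from compound 1 to compound 2 (beyond the scatter), is modest and lies beyond the scatter. Compound 1, at 30%, carries 5-carboxy-2-methoxyphenyl, so a value near that of compound 1 is expected, with wide uncertainty. For compound 4 the estimate is 32%, with an expected range of 12% to 60%.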

Compound 4, percent of the compound remaining: 15%
The estimate for compound 4 lay 17 percentage points above the measured number; measured number inside the range.
By their numbers in this assay, from the lowest: compounds 2 and 4 (each within the scatter of the next); then compound 1.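

In this assay, the swap of chloro for methoxy gives a number 15 percentage points lower from compound 1 to compound 4 (beyond the scatter) and shows that this single group on the 5-carboxyphenyl ring matters, which the earlier pair, differing in more than one group, could not isolate. The other comparison, a number 6 percentage points higher from compound 2 to compound 4 (within the scatter), does not separate 5-carboxy-2-chlorophenyl from 3-carboxy-4-hydroxyphenyl. No measurement at hand explains either step. The step from compound 3 to compound 4 cannot be read, since compound 3 has no number. Going by these compounds, whether a fluoro, a methyl or an amine in place of the chloro would change the read-out stays open.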